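Removing One Methoxy Group: Expected Effect on Cytotoxicity

The source may hold more compounds than are shown below. What is called first, only, known or untested is meant among the compounds shown, and "the series" means these compounds.

Compound 1, `COc1cc(-c2cc(/C=C/C(=O)c3ccc(N)cc3)[nH]n2)cc(OC)c1OC`: -89%
Compound 2, `COc1ccc(-c2cc(/C=C/C(=O)c3ccc(N)cc3)[nH]n2)cc1OC`: -88%
Compound 3, `COc1cc(C(=O)/C=C/c2cc(-c3cc(OC)c(OC)c(OC)c3)n[nH]2)cc(OC)c1OC`: -99%

Three compounds were measured in a functional assay on NCI-H322M cells (Homo sapiens) for cytotoxicity, read by sulforhodamine B assay, with a stated time of 48 h, tested at 100 uM; on this read-out higher numbers stand for a weaker effect at the one concentration tested and lower numbers for a stronger effect. Compound 1 gives -89% and compound 2 gives -88%; the two differ by hydrogen in place of methoxy on an aromatic carbon, and the step of a number 1 percentage points higher from compound 1 to compound 2 (within the scatter) is small. Compound 3 gives -99%, the lowest of the three numbers; the difference between its core and that of compound 1 is not broken down here, and the values of compound 1 and compound 3 lie within the scatter of each other, while compound 2 stands beyond it.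

Compound 4, `COc1ccc(-c2cc(/C=C/C(=O)c3cc(OC)c(OC)c(OC)c3)[nH]n2)cc1OC`, has not yet been measured in this assay. It differs from compound 3 by hydrogen in place of methoxy on an aromatic carbon, the same change as that from compound 1 to compound 2, at a place described in the same words. Because a number 1 percentage points higher from compound 1 to compound 2 (within the scatter) was within the scatter, the expected step is a number 2 percentage points higher from compound 3 to compound 4 (within the scatter). Compound 4 is therefore expected to give about -97%, estimated between -100% and -86%.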

Compound 4, a percentage reported as activity, at one concentration (the size of the read-out at that concentration, not a potency): -91%
Estimate against measurement, compound 4: 6 percentage points below; the measured number falls inside the stated range.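

In this assay, hydrogen in place of methoxy on an aromatic carbon gives a number 8 percentage points higher from compound 3 to compound 4 (within the scatter) on the core of compound 3, and the step seen on the core of compound 1 is a number 1 percentage points higher from compound 1 to compound 2 (within the scatter). Both steps lie within the scatter and cannot be told apart, so within this series the change carries from one core to the other without a detectable difference: the same change on two cores in this assay, a number 1 percentage points higher (within the scatter) from compound 1 to compound 2 and a number 8 percentage points higher (within the scatter) from compound 3 to compound 4, 7 percentage points apart, within the scatter of two such steps. Going by these compounds alone, this rests on only two pairs, each read at a single concentration, so it shows that neither core separates the two compounds of its pair at that concentration, but it gives no measure of potency and no proof that the change is without effect on other cores.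

On these data alone, it remains open whether a hydroxyl, a chlorine or a longer ethoxy chain in place of the methoxy would give an equally small step. The compounds shown also leave open what a carboxylic acid at that place would do on either core.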